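A few compounds are considered here, and "the series" means these few. Any claim that something is new, unique, unknown or untested is made for them only; others in the source may bear on it.

Values in a functional assay on HepG2 cells (Homo sapiens) for cytotoxicity, read by sulforhodamine B assay, with a stated time of 24 h (a lower number here means a stronger inhibitor, a higher number a weaker inhibitor), follow.
- compound 1 `O=C1Nc2ccc(S(=O)(=O)N3CCOCC3)cc2/C1=N/c1ccc(O)cc1` gives 10400 nM
- compound 2 `O=C1Nc2ccc(S(=O)(=O)N3CCOCC3)cc2/C1=N/c1cccc(C(F)(F)F)c1` gives 14300 nM
- compound 3 `O=C1Nc2ccc(S(=O)(=O)N3CCOCC3)cc2/C1=N/Nc1ccccc1` gives 15600 nM

Compound 3 lies within the scatter of both other compounds, so the three cannot be ranked. Compound 4 `O=C1Nc2ccc(S(=O)(=O)N3CCOCC3)cc2/C1=N/NS(=O)(=O)c1ccccc1` carries phenylsulfonyl in place of phenyl on an amine nitrogen of compound 3 (phenylsulfonyl in place of phenyl on an amine nitrogen). Going by the values given here, no measured step tests this group directly. The closest evidence comes from changes on the double-bonded nitrogen, namely a 1.5-fold higher number from compound 1 to compound 3 (0.18 log units; within the scatter) and a 1.1-fold higher number from compound 2 to compound 3 (0.04 log units; within the scatter), together with a 1.4-fold higher number from compound 1 to compound 2 (0.14 log units; within the scatter). All three stay within the scatter, so no step beyond it is expected in this assay, although the data hold no sulfonyl comparison. The expected change is a 1.2-fold lower number from compound 3 to compound 4 (0.08 log units; within the scatter). Compound 4 is estimated at 13000 nM, with an expected range of 6000 nM to 28000 nM.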

Compound 4, half-maximal inhibitory concentration: 23900 nM
Compound 4: middle estimate off by 1.8-fold (0.26 log units), on the low side, within the range that was stated.
By their numbers in this assay, from the lowest: compounds 1, 2, 3 and 4 (each within the scatter of the next, the first and the last beyond it).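

Going by these compounds alone, with phenylsulfonyl on the amine nitrogen, the only sulfonyl group, this assay shows a 1.5-fold higher number from compound 3 to compound 4 (0.19 log units; within the scatter) and a 1.7-fold higher number from compound 2 to compound 4 (0.22 log units; within the scatter), so this change stays close to the anilino and 3-(trifluoromethyl)phenyl compounds. Against the 4-hydroxyphenyl compound, the same assay gives a 2.3-fold higher number from compound 1 to compound 4 (0.36 log units; beyond the scatter), the only modest separation in the series. Nothing measured here explains that separation.

Open, on these data alone, is whether methylsulfonyl in place of phenylsulfonyl would keep these numbers. Also open, as far as these compounds go, is what an amine or a carboxylic acid on the phenyl ring of phenylsulfonyl would do.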